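The source may hold more compounds than are shown below. What is called first, only, known or untested is meant among the compounds shown, and "the series" means these compounds.

Compound 2 `O=C(Nc1cccc(-n2cc(-c3ccncc3)c(-c3cc(O)cc(Cl)c3)n2)c1)Nc1ccc(Cl)c(C(F)(F)F)c1`: 14.3%
Compound 1 `COc1cc(Cl)cc(-c2nn(-c3cccc(NC(=O)c4ccc(Cl)c(Cl)c4)c3)cc2-c2ccncc2)c1`: 36.1%

In a functional assay on SF-295 cells (Homo sapiens) for inhibition, read by sulforhodamine B assay, with a stated time of 48 h, tested at 10 uM (on this read-out lower numbers stand for a stronger effect and higher numbers for a weaker effect at the one concentration tested), compound 2 gives 14.3%, the lowest of the two numbers shown. Among the measured compounds shown here, compound 1 gives 36.1%, a number higher by more than the usual scatter, and no single-point step links these two structures, so their gap cannot be traced to one change. Compound 3 `O=C(Nc1cccc(-n2cc(-c3ccncc3)c(-c3cc(O)cc(Cl)c3)n2)c1)Nc1ccc(Cl)c(Cl)c1` has not been measured. It differs from compound 2 in one place: chloro in place of trifluoromethyl on an aromatic carbon. No hydrogen-bond donor or acceptor is lost or gained in this change, and the group that leaves counts more heavy atoms than the one that enters. The step in this assay is expected to be small, if any, with a slight lean toward a higher number. The expected step is a number 5.7 percentage points higher from compound 2 to compound 3 (within the scatter). Compound 3 is therefore estimated at 20%, with a plausible range from 8% to 40%.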

Compound 3, a percentage reported as activity, at one concentration (the size of the read-out at that concentration, not a potency): -50.5%
Beside the measured number, compound 3's estimate is 70.5 percentage points above it; measured number below the stated range.
By their numbers in this assay, from the lowest: compound 3; then compound 2; then compound 1.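

Changing trifluoromethyl to chloro on this aromatic carbon, ortho to a chloro group, gives a large step in this assay: a number 64.8 percentage points lower from compound 2 to compound 3 (beyond the scatter). The earlier compounds shown here could not show this, as no single-change pair linked them, whereas this pair isolates one position and shows that the read-out can respond strongly to what sits there. The change involves no hydrogen-bond donor or acceptor and leaves fewer heavy atoms at this place, and the 3,4-dichlorophenyl of compound 3 takes the number to -50.5%, below zero.

No measurement shown accounts for a step of this size. Going by these compounds, whether a bromine, a nitrile or an amine on this same carbon would give a number nearer compound 2 or compound 3 stays open, and this single pair cannot establish a wider trend.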